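Adding a chloro group beside the trifluoromethyl in a urea series

The source may report more compounds than this note shows. Statements on the series, on what has been measured and on what is new or still open speak of the compounds shown alone.

Measured compounds:
- compound 1, `COc1cc2cc(Oc3ccc(NC(=O)Nc4ccc(C(F)(F)F)cc4)cc3)c(C)nc2cc1OC`: 79.3%
- compound 2, `COc1cc2cc(Oc3ccc(NC(=O)Nc4cccc(C(F)(F)F)c4)cc3)c(C)nc2cc1OC`: 29.2%

Both compounds were tested in a functional assay on SF-268 cells (Homo sapiens) for inhibition, read by sulforhodamine B assay, with a stated time of 48 h, tested at 10 uM; on this read-out lower numbers stand for a stronger effect and higher numbers for a weaker effect at the one concentration tested. Compound 2 gives the lowest of the two numbers, and on this read-out that means the stronger effect; the nearest number is that of compound 1, the step of a number 50.1 percentage points lower from compound 1 to compound 2 (beyond the scatter) lying beyond the scatter.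

Compound 3, `COc1cc2cc(Oc3ccc(NC(=O)Nc4ccc(Cl)c(C(F)(F)F)c4)cc3)c(C)nc2cc1OC`, has not yet been measured. It differs from compound 2 by chloro in place of hydrogen on an aromatic carbon. Going by the values given here, the only measured step, from compound 1 to compound 2, concerns a change of a different kind, so no measured step bears directly on this new change. With no comparison to lean on, only a small shift is expected, in either direction, and the number for compound 3 is estimated to stay close to that of compound 2, as a number 4.2 percentage points lower from compound 2 to compound 3 (within the scatter). The expected value for compound 3 is 25%, with a range from 8% to 50%.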

Compound 3, a percentage reported as activity, at one concentration (the size of the read-out at that concentration, not a potency): -10.2%
Beside the measured number, compound 3's estimate is 35.2 percentage points above it; measured number below the stated range.
By their numbers in this assay, from the lowest: compound 3; then compound 2; then compound 1.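

In this assay, the earlier pair showed only that the place of the trifluoromethyl group matters, whereas this result shows that adding one chlorine atom to the same ring, ortho to the trifluoromethyl group and para to a large group, also counts, giving a number 39.4 percentage points lower from compound 2 to compound 3 (beyond the scatter) in the direction of a stronger effect. Set against the first compound, the 4-chloro-3-(trifluoromethyl)phenyl group gives a number 89.5 percentage points lower from compound 1 to compound 3 (beyond the scatter), so this position can hold a substituent without losing the effect at the one concentration tested. Nothing in hand explains why chloro has this effect.

The compounds shown leave open whether chloro is special here, or whether a fluoro, a methyl or an amine on the same carbon would move the number as far. They also leave open how the compounds rank at other concentrations.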